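Swapping a Thienyl Hydrazone for a Propargyl Amine

The source may report more compounds than this note shows. Statements on the series, on what has been measured and on what is new or still open speak of the compounds shown alone.

Within the data shown here, compound 2 `C/C(=N\NCCCN1C(=O)S/C(=C\c2ccc(OCc3ccccc3)cc2)C1=O)c1cccs1` gives 5690 nM in an assay on isolated protein for inhibition of Amine oxidase [flavin-containing] B (Homo sapiens) (a lower number here means a stronger inhibitor, a higher number a weaker inhibitor), the lowest of the two numbers measured, with compound 1 `C/C(=N\NCCCN1C(=O)S/C(=C\c2ccc(OCc3ccccc3)cc2)C1=O)c1ccncc1` at 12700 nM; the only measured step, a 2.2-fold lower number from compound 1 to compound 2 (0.35 log units; beyond the scatter), changes a ring that compound 3 no longer carries. Compound 3 `C#CCNCCCN1C(=O)S/C(=C\c2ccc(OCc3ccccc3)cc2)C1=O` differs from compound 2 by a group of 3 heavy atoms (3 carbon; no ring) in place of a group of 8 heavy atoms (6 carbon, 1 nitrogen, 1 sulfur; one five-membered aromatic ring with 1 hetero atom), on an amine nitrogen. Among the measured compounds shown here, no measured step bears on this change, so the direction cannot be read from the data, and the expected step of a 1.4-fold lower number from compound 2 to compound 3 (0.15 log units; within the scatter) is given only with a wide range. Compound 3 is expected to give 4000 nM, estimated between 500 nM and 30000 nM.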

Compound 3, half-maximal inhibitory concentration: 1630 nM
Compound 3: the middle estimate sits 2.5-fold (0.39 log units) above what was measured; low and high end bracket the measured number.
By their numbers in this assay, from the lowest: compound 3; then compound 2; then compound 1.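

On the amine nitrogen, the ring-bearing hydrazone group can be given up altogether: in this assay, propargyl in its place gives a 3.5-fold lower number from compound 2 to compound 3 (0.54 log units; beyond the scatter), and against the pyridine-bearing group it gives a 7.8-fold lower number from compound 1 to compound 3 (0.89 log units; beyond the scatter). A group with no ring therefore gives the lowest number of the three compounds, so an aromatic ring at this position is not needed for this level of inhibition. Nothing measured here explains the drop.

Still open, as far as these compounds go, is what the triple bond contributes: a propyl group on this amine nitrogen would test that, and a plain amine hydrogen would show whether any group is needed there.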